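Thiophene in Place of Methylfuran on the Amide Carbonyl

The source may hold more compounds than are shown below. What is called first, only, known or untested is meant among the compounds shown, and "the series" means these compounds.

Among the measured compounds shown here, compound 2 `Cc1ccc(C(=O)Nc2ccc(N3CCN(c4ccc(OC[C@@H]5CO[C@@](Cn6cncn6)(c6ccc(Cl)cc6Cl)O5)cc4)CC3)cc2)o1` holds the lowest of the two numbers measured so far: in a functional assay on HepG2 cells (Homo sapiens) for inhibition, read by MTT assay, with a stated time of 48 h (a lower number here means a stronger inhibitor, a higher number a weaker inhibitor), compound 2 gives 8700 nM, while compound 1 `O=C(Nc1ccc(N2CCN(c3ccc(OC[C@@H]4CO[C@@](Cn5cncn5)(c5ccc(Cl)cc5Cl)O4)cc3)CC2)cc1)c1ccco1` gives 22300 nM. Compound 3 `O=C(Nc1ccc(N2CCN(c3ccc(OC[C@@H]4CO[C@@](Cn5cncn5)(c5ccc(Cl)cc5Cl)O4)cc3)CC2)cc1)c1cccs1` differs from compound 2 by thiophen-2-yl in place of 5-methylfuran-2-yl on a carbonyl carbon. For the measured compounds named here, only one measured step bears on this change, a 2.6-fold lower number from compound 1 to compound 2 (0.41 log units; beyond the scatter), and it concerns the methyl that now leaves; the exchange of the ring hetero atom has no measured counterpart. The step from compound 2 to compound 3 is therefore expected to run back toward compound 1, by a 1.8-fold higher number from compound 2 to compound 3 (0.26 log units; within the scatter). For compound 3 the estimate is 16000 nM, with a range from 6000 nM to 40000 nM.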

Compound 3, half-maximal inhibitory concentration: 9770 nM
Compound 3: the middle estimate sits 1.6-fold (0.21 log units) above what was measured; the measured number falls inside the stated range.
By their numbers in this assay, from the lowest: compounds 2 and 3 (each within the scatter of the next); then compound 1.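

Thiophen-2-yl on the carbonyl carbon cannot be told apart from 5-methylfuran-2-yl in this assay with a 1.1-fold higher number from compound 2 to compound 3 (0.05 log units; within the scatter) and so matches the methylated ring without a methyl. Among the compounds shown here, exchanging the ring hetero atom alone gives a 2.3-fold lower number from compound 1 to compound 3 (0.36 log units; beyond the scatter), which shows that the methyl is not the only change from furan-2-yl that lowers the number. No evidence accounts for this result. The compounds shown leave open whether a methyl on the thiophen-2-yl ring would lower the number further. They also leave open how an amine or a longer chain on the carbonyl carbon would read in this assay.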